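Swapping the Cyano Group for Methoxy on the Aryl Ring

The source may report more compounds than this note shows. Statements on the series, on what has been measured and on what is new or still open speak of the compounds shown alone.

Measured compounds:
compound 1, `CC(C)c1ccc(-c2nc3sccn3c2/C=N/OCc2ccc(Cl)c(Cl)c2)cc1`: 590 nM
compound 2, `FC(F)(F)c1ccc(-c2nc3sccn3c2/C=N/OCc2ccc(Cl)c(Cl)c2)cc1`: 880 nM
compound 3, `N#Cc1ccc(-c2nc3sccn3c2/C=N/OCc2ccc(Cl)c(Cl)c2)cc1`: 3400 nM

In an assay on HepG2 cells for agonist activity at nuclear receptor subfamily 1 group I member 3 (Homo sapiens), read by a luciferase reporter, with a stated time of 23 h (a lower number here means that less compound is needed, a higher number that more compound is needed for the effect), compound 3 gives the highest number of the three, so the most compound is needed for the effect. Both earlier steps that end in compound 3 bear on the next change: a 5.8-fold higher number from compound 1 to compound 3 (0.76 log units; beyond the scatter) and a 3.9-fold higher number from compound 2 to compound 3 (0.59 log units; beyond the scatter), each a modest rise once cyano entered. The unmeasured compound 4 is `COc1ccc(-c2nc3sccn3c2/C=N/OCc2ccc(Cl)c(Cl)c2)cc1`. Compared with compound 3 the change is methoxy in place of cyano on an aromatic carbon. Since each shown step toward cyano raised the number, removing cyano is expected to lower it modestly, as a 2.3-fold lower number from compound 3 to compound 4 (0.36 log units; beyond the scatter). Compound 4 is therefore estimated at 1500 nM, with a likely range from 500 nM to 4500 nM.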

Compound 4, half-maximal effective concentration: 490 nM
Compound 4: the middle estimate sits 3.1-fold (0.49 log units) above what was measured; the whole stated range lies above it.
By their numbers in this assay, from the lowest: compounds 4, 1 and 2 (each within the scatter of the next); then compound 3.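

Methoxy brings the number back down from the cyano compound, with a 6.9-fold lower number from compound 3 to compound 4 (0.84 log units; beyond the scatter). It cannot be told apart from the other two groups at this position, with a 1.8-fold lower number from compound 2 to compound 4 (0.25 log units; within the scatter) and a 1.2-fold lower number from compound 1 to compound 4 (0.08 log units; within the scatter), both within the scatter. Among the four compounds shown, cyano alone stands apart, while methoxy, trifluoromethyl and isopropyl give numbers that lie together.

No measurement shown explains why cyano differs from the other three groups. Going by these compounds, whether an amine, a carboxylic acid or a longer chain on this aromatic carbon would match those three groups or side with cyano remains open.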